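This account rests on a few compounds, and the source may have more. Where it says the series, first, only, none or still open, it means among the compounds named here.

In a toxicity assay on MT2 cells (Homo sapiens) for cytotoxicity, read by MTT assay (on this read-out higher numbers stand for lower toxicity in this test and lower numbers for higher toxicity in this test), compound 1 `N#Cc1ccc2ccc(Oc3ccccc3OCCn3ccc(=O)[nH]c3=O)cc2c1` gives 15000 nM. Compound 2 `CCCc1cc(Oc2ccccc2OCCn2ccc(=O)[nH]c2=O)c(C)c2cc(C#N)ccc12` gives 15000 nM in the same this assay, level with compound 1 at the digits shown, and the two values fall within the usual scatter of each other, so nothing can be said of any difference between them. For the measured compounds named here, no pair of measured compounds here differs in a single place, so no measured step is available to show how a single change moves the read-out.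

Compound 3 `COCc1cc(Oc2ccccc2OCCn2ccc(=O)[nH]c2=O)c(C)c2cc(C#N)ccc12` has not yet been measured in this assay. Going by the values given here, its single difference from compound 2 is this: methoxy in place of ethyl on a saturated chain carbon bound to an aromatic carbon. Nothing in the measured pair bears on this change, since compound 1 and compound 2 differ in several places at once and still sit at the same level.

Compound 3 is therefore expected to stay close to compound 2, and the step from compound 2 to compound 3 in this assay is estimated at no change at the digits printed from compound 2 to compound 3 (within the scatter), none beyond the scatter. For compound 3 the expected value in this assay is 15000 nM, with a range from 7000 nM to 32000 nM.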

Compound 3, half-maximal cytotoxic concentration: 16000 nM
For compound 3 the middle estimate is 1.1-fold (0.03 log units) below the measured one; the range from low to high includes it.
By their numbers in this assay, from the lowest: compounds 1, 2 and 3 (each within the scatter of the next).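

In this assay, for the compounds shown here, methoxy in place of ethyl on a saturated chain carbon bound to an aromatic carbon gives a 1.1-fold higher number from compound 2 to compound 3 (0.03 log units; within the scatter), and this is the first step here that isolates a single place. The same difference, read one bond further out, is propyl to methoxymethyl: a carbon gives way to an oxygen and a hydrogen-bond acceptor enters, yet this read-out separates compound 2 from compound 3 by no more than the scatter, so at this place the exchange leaves no measurable mark on toxicity in this test. No measured information bears on why the two compounds sit so close.

This one step covers a single exchange at a single place, so it does not say whether the level would hold for other groups on this carbon. An amine, a carboxylic acid or a longer chain such as butyl could stay level with compound 2 or could move the read-out beyond the scatter, and the compounds shown do not decide between these outcomes.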